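The source may hold more compounds than are shown below. What is called first, only, known or untested is meant among the compounds shown, and "the series" means these compounds.

In a functional assay on HepG2 cells (Homo sapiens) for cytotoxicity, read by sulforhodamine B assay, with a stated time of 24 h (a lower number here means a stronger inhibitor, a higher number a weaker inhibitor), three compounds that share one core have been measured. Compound 1 (`Cc1ccc(S(=O)(=O)N/N=C2\C(=O)Nc3ccc(S(=O)(=O)N4CCOCC4)cc32)cc1`) gives 24700 nM in this test and compound 2 (`CC(=O)N/N=C1\C(=O)Nc2ccc(S(=O)(=O)N3CCOCC3)cc21`) gives 27500 nM in the same test. Compound 3 (`N/N=C1\C(=O)Nc2ccc(S(=O)(=O)N3CCOCC3)cc21`) gives 32400 nM and so stands level with the other two, within the scatter of both. Changing the group on the amine nitrogen gave a 1.1-fold higher number from compound 1 to compound 2 (0.05 log units; within the scatter) and a 1.3-fold higher number from compound 1 to compound 3 (0.12 log units; within the scatter) and a 1.2-fold higher number from compound 2 to compound 3 (0.07 log units; within the scatter) so none of the three steps stands out from the scatter.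

Compound 4 (`O=C1Nc2ccc(S(=O)(=O)N3CCOCC3)cc2/C1=N/c1ccc(Cl)cc1`) has 4-chlorophenyl in place of amino on a double-bonded nitrogen. Among the compounds with values here, no measured compound carries this group, so the three small steps guide the expectation only loosely. They give no reason to expect a large move in this assay in either direction. The expected change is a 1.6-fold lower number from compound 3 to compound 4 (0.21 log units; within the scatter) and that small drop would not be a step beyond the scatter. Compound 4 is expected near 20000 nM in this test. The estimated range runs from 7000 nM to 45000 nM for repeated measurements.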

Compound 4, half-maximal inhibitory concentration: 11800 nM
Beside the measured number, compound 4's estimate is 1.7-fold (0.23 log units) above it; the range from low to high includes it.
By their numbers in this assay, from the lowest: compound 4; then compounds 1, 2 and 3 (each within the scatter of the next).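

In this assay, the group on the double-bonded nitrogen can move the number beyond the scatter: 4-chlorophenyl in place of amino gives a modest drop (a 2.7-fold lower number from compound 3 to compound 4 (0.44 log units; beyond the scatter)), and 4-chlorophenyl in place of acetamido gives a similar one (a 2.3-fold lower number from compound 2 to compound 4 (0.37 log units; beyond the scatter)). Among compounds 1, 2 and 3, the changes at this spot stayed within the scatter, so compound 4 is the first sign that this position responds at all, though only modestly. Nothing measured here explains the drop. The compounds shown leave open whether the six-membered aromatic ring or its chlorine accounts for the step. Phenyl without chlorine, 4-methoxyphenyl or a saturated ring such as cyclohexyl on this nitrogen would help to separate the two, and a single compound cannot show a trend.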